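Swapping the Amine Link on a Weak Kinase Inhibitor

This account rests on a few compounds, and the source may have more. Where it says the series, first, only, none or still open, it means among the compounds named here.

Measured compounds:
compound 1 `Cn1cc(-c2n[nH]c3ccc(N[C@@H]4CCNC4)cc23)cn1` with 37000 nM
compound 2 `O=C1CC(c2ccccc2)=NN1` with 13000 nM

Compound 1 `Cn1cc(-c2n[nH]c3ccc(N[C@@H]4CCNC4)cc23)cn1` was tested in an assay on isolated protein for inhibition of tyrosine-protein kinase receptor UFO (Homo sapiens), with a stated time of 1.5 h (on this read-out lower numbers stand for stronger inhibition and higher numbers for weaker inhibition), and gave 37000 nM. Of the two numbers available it is the higher one; compound 2 `O=C1CC(c2ccccc2)=NN1` in this assay gave 13000 nM, a lower number, and the gap between the two lies beyond the usual scatter. Compound 2 shares no common core with compound 1, so its value serves only as a second point of reference.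

Compound 3 `CNC1CCN(c2ccc3[nH]nc(-c4cnn(C)c4)c3c2)C1` has not been measured. It differs from compound 1 in one place: 3-(methylamino)pyrrolidin-1-yl in place of (pyrrolidin-3-yl)amino on an aromatic carbon. Going by the values given here, no measured pair shows what such a change does in this assay, so the direction of the step is open. A difference of this kind, on a compound this weak, is expected to move the number only modestly, and the expected step of a 1.5-fold lower number from compound 1 to compound 3 (0.17 log units; within the scatter) is not taken to lie clearly beyond the scatter in either direction. Compound 3 is therefore expected to give about 25000 nM, within a range from 8000 nM to 80000 nM.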

Compound 3, half-maximal inhibitory concentration: 432000 nM
Estimate against measurement, compound 3: 17-fold (1.24 log units) below, outside the stated range (above it).
By their numbers in this assay, from the lowest: compound 2; then compound 1; then compound 3.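

In this assay, this aromatic carbon of the shared core proves sensitive to how the amine is attached: placing 3-(methylamino)pyrrolidin-1-yl in place of (pyrrolidin-3-yl)amino gives a 12-fold higher number from compound 1 to compound 3 (1.07 log units; beyond the scatter) and marks a large change on a compound that was already weak. The two groups are closely matched on paper, as each holds one five-membered non-aromatic ring with 1 hetero atom and neither carries a net charge. The entering group has 1 hydrogen-bond donor against 2 and no defined stereocentre, but nothing measured here bears on why the number rises, and this single pair cannot separate those differences.

The compounds shown leave open which part of the change goes with the higher number, the ring nitrogen on the aromatic carbon or the methylamino group on the ring. They also leave open how a primary amine on the same pyrrolidine ring, or a piperidine ring or open-chain amine at this position, would read in this assay.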